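Adding a methyl to a pyrimidinone side chain: cytotoxicity unchanged?

The source may hold more compounds than are shown below. What is called first, only, known or untested is meant among the compounds shown, and "the series" means these compounds.

Compound 1 `CC(C)c1c(Cc2c(F)cccc2Cl)nc(SCC(=O)c2ccc(F)cc2)[nH]c1=O` and compound 2 `CCC(C)c1c(Cc2c(F)cccc2Cl)nc(SCC(=O)c2ccc(F)cc2)[nH]c1=O` share a core and differ by methyl in place of hydrogen on a saturated chain carbon, two bonds along the chain from an aromatic carbon. In an ADME assay on MT4 cells (Homo sapiens) for cytotoxicity, read by MTT assay (on this read-out lower numbers stand for higher toxicity in this test and higher numbers for lower toxicity in this test), compound 1 gives > 56000 nM, a limit of the assay rather than a number. In this assay compound 2 gives > 54000 nM, likewise only a limit. The step that the two limits leave unreadable from compound 1 to compound 2 therefore cannot be read, as both values sit at limits the limit of > 54000 nM in this assay, at which 1 of the 3 values shown sits, and (the limit of > 56000 nM in this assay, at which 1 of the 3 values shown sits). Compound 3 `Cc1c(Cc2c(F)cccc2F)nc(SCC(=O)c2ccccc2)[nH]c1=O` has a different core; the difference between the two cores is not broken down here. In this assay, for the measured compounds named here, compound 3 gives 65000 nM, the only number among the three. Compound 4 `CCc1c(Cc2c(F)cccc2F)nc(SCC(=O)c2ccccc2)[nH]c1=O` differs from compound 3 by methyl in place of hydrogen on a saturated chain carbon bound to an aromatic carbon, the same kind of change as before, though here the carbon is bound to an aromatic carbon rather than two bonds along the chain from one. With no readable precedent, compound 4 is expected to stay close to compound 3, a step of a 1.1-fold lower number from compound 3 to compound 4 (0.03 log units; within the scatter). Compound 4 is thus estimated at 60000 nM.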

Compound 4, half-maximal cytotoxic concentration: 56000 nM
For compound 4 the middle estimate is 1.1-fold (0.03 log units) above the measured one; measured number inside the range.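

In this assay methyl in place of hydrogen on a saturated chain carbon bound to an aromatic carbon gives a 1.2-fold lower number from compound 3 to compound 4 (0.06 log units; within the scatter) and so leaves the read-out within the scatter on the core of compound 3. On the core of compound 1, where the change sits two bonds along the chain from an aromatic carbon, the step to compound 2 cannot be read, because both compounds stand at limits of the assay: the limit of > 54000 nM in this assay, at which 1 of the 4 values shown sits. The result therefore holds for the core of compound 3 alone and does not show that the change behaves alike on another core.

The compounds shown leave open how a longer chain or an amine at this place would read in this assay. They also leave open whether any such group would give a step beyond the scatter on either core.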